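The compounds below may be only part of what the source reports. "The series", "measured", "known", "first", "only" and "open" are said of these compounds alone.

Measured so far in a functional assay on B16-F10 cells (Mus musculus) for cytotoxicity, read by CCK-8 assay, with a stated time of 48 h; on this read-out lower numbers stand for stronger inhibition and higher numbers for weaker inhibition:
compound 1 `NS(=O)(=O)c1ccc(/N=C/c2c(Cl)c3ccccc3oc2=O)cc1` gives 300 nM
compound 2 `CC(C)(C)c1cc(C(C)(C)C)c2oc(=O)c(/C=N/c3ccc(S(=O)(=O)Nc4nccs4)cc3)c(Cl)c2c1` gives 160 nM

Of the two numbers, compound 2 has the lower one, but the gap to compound 1 is within the scatter of repeated measurements, so the two compounds are not separated on this read-out. Both carry the same chlorinated coumarin imine core and a sulfonamide on the aniline; compound 2 adds two tert-butyl groups on that core and an aromatic substituent on the sulfonamide nitrogen.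

Compound 3 `Cc1ccnc(NS(=O)(=O)c2ccc(/N=C/c3c(Cl)c4cc(C(C)(C)C)cc(C(C)(C)C)c4oc3=O)cc2)n1` is not yet measured. It keeps the core and the tert-butyl groups of compound 2 and differs only at the sulfonamide nitrogen: 4-methylpyrimidin-2-yl in place of 1,3-thiazol-2-yl on a sulfonamide nitrogen. Going by the values given here, no measured pair shows this exchange, and the two values seen so far give no hint of a direction for a change at this position. Both hetero-aromatic groups count 0 hydrogen-bond donors and 2 hydrogen-bond acceptors.

The step from compound 2 to compound 3 is therefore expected to be a 1.1-fold higher number from compound 2 to compound 3 (0.05 log units; within the scatter), no further than the scatter in either direction. For compound 3 in this assay the estimate is 180 nM, with a range from 70 nM to 450 nM.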

Compound 3, half-maximal inhibitory concentration: 190 nM
Compound 3: the middle estimate sits 1.1-fold (0.02 log units) below what was measured, within the range that was stated.
By their numbers in this assay, from the lowest: compounds 2, 3 and 1 (each within the scatter of the next).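

In this assay, going by these compounds alone, the exchange of 1,3-thiazol-2-yl for 4-methylpyrimidin-2-yl on a sulfonamide nitrogen gives a 1.2-fold higher number from compound 2 to compound 3 (0.07 log units; within the scatter) with the shared core and both tert-butyl groups held fixed, the first matched reading at this position. On this read-out, a five-membered aromatic ring of 5 heavy atoms and a six-membered aromatic ring of 7 heavy atoms are therefore not separated at this place, although this rests on a single pair. No supporting measurement on hand bears on this result.

Both groups shown on the sulfonamide nitrogen are aromatic rings with 2 hetero atoms, so it remains open whether a plain phenyl ring, a short alkyl chain or a ring bearing a carboxylic acid or an amine would read the same in this assay. The contributions of the two tert-butyl groups and of the sulfonamide nitrogen substituent also remain unresolved, since compound 1 differs from compound 2 in more than one place.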